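The source may hold more compounds than are shown below. What is called first, only, known or untested is meant among the compounds shown, and "the series" means these compounds.

Among the compounds with values here, compound 1 `CC(C)[C@@H](NC(=O)/C=C/c1ccncc1-c1ccc2ccccc2c1)C(=O)O` is one of two compounds measured in an assay on a protein complex for inhibition of CDK8/Cyclin C (Homo sapiens), with a stated time of 1 h, tested at 10 uM; on this read-out lower numbers stand for less inhibition and higher numbers for more inhibition at the one concentration tested (going by the name of the read-out). In this assay compound 1 gives 77%, the lower of the two numbers. Compound 2 `Cn1ncc2cc(-c3cnccc3/C=C/C(=O)N3CCOCC3)ccc21` gives 95% in this assay, a number higher by a margin beyond the usual scatter of repeated measurements. Compound 3 `O=C(O)[C@@H]1CCCN1C(=O)/C=C/c1ccncc1-c1ccc2ccccc2c1` has not been measured yet. It differs from compound 1 at a single place: 2-carboxypyrrolidin-1-yl in place of (1-carboxy-2-methylpropyl)amino on a carbonyl carbon. The carboxy group stays, and the group that carries it now forms one five-membered non-aromatic ring. Within the data shown here, no step between two measured compounds is available as a guide, so the expectation rests on the value of compound 1, 77%, alone. The expected step is a number 3 percentage points higher from compound 1 to compound 3 (within the scatter), which is not beyond the scatter in either direction. Compound 3 is therefore estimated at 80%, with a likely range from 60% to 95%.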

Compound 3, a percentage reported as inhibition, at one concentration (the size of the read-out at that concentration, not a potency): 67%
Compound 3: middle estimate off by 13 percentage points, on the high side; measured number inside the range.
By their numbers in this assay, from the lowest: compounds 3 and 1 (each within the scatter of the next); then compound 2.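

At this carbonyl carbon, replacing (1-carboxy-2-methylpropyl)amino with 2-carboxypyrrolidin-1-yl gives a number 10 percentage points lower from compound 1 to compound 3 (within the scatter) in this assay. The open chain can therefore be closed into a five-membered non-aromatic ring, with the carboxy group kept and one hydrogen-bond donor fewer, without a step beyond the scatter at the one concentration tested. No measurement is available that would explain this result.

As far as these compounds go, it remains open what a methyl ester in place of the carboxylic acid would give at this carbonyl carbon, which would test whether the free carboxy group matters here. From the compounds shown here alone, the effect of a six-membered ring, as in a piperidine-2-carboxylic acid amide, or of a longer chain carrying the carboxy group also remains unknown.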